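Amide Nitrogen Substituents on a Bicyclic Imidazole Core

A few compounds are considered here, and "the series" means these few. Any claim that something is new, unique, unknown or untested is made for them only; others in the source may bear on it.

Measured so far:
compound 1, `CN(C)C(=O)Cn1c(-c2ccc(Cl)cc2)nc2cccnc21`: 4.1 mg/kg
compound 2, `CN(C)C(=O)Cn1c(-c2ccc(Br)s2)nc2cccnc21`: 100 mg/kg

Among the compounds with values here, of the two measured compounds, compound 1 stands at the lower number in a functional assay on the whole organism with Mus musculus as the target; a lower number here means that less compound is needed, a higher number that more compound is needed for the effect; compound 2 is its only neighbour, and the step of a 24-fold higher number from compound 1 to compound 2 (1.39 log units; beyond the scatter) is large. Compound 3, `CCCCN(CCCC)C(=O)Cn1c(-c2ccc(Cl)cc2)nc2cccnc21`, has not yet been measured. It keeps the 4-chlorophenyl group of compound 1 and differs only in the amide: dibutylamino in place of dimethylamino on a carbonyl carbon. Within the data shown here, the single measured step concerns a change on an aromatic carbon and so gives no guidance for a change at the carbonyl carbon; nothing measured here bears on the new amide. Among the measured compounds shown here, with no step to lean on, the expected change a 2.0-fold higher number from compound 1 to compound 3 (0.29 log units; within the scatter) is centred close to no change, but with a wide range in either direction. Compound 3 is therefore expected to give 8 mg/kg in this assay, within 2 mg/kg to 40 mg/kg.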

Compound 3, dose for half-maximal effect: 38 mg/kg
For compound 3 the middle estimate is 4.8-fold (0.68 log units) below the measured one; measured number inside the range.
By their numbers in this assay, from the lowest: compound 1; then compound 3; then compound 2.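

The amide turns out to be a position that matters on its own: dibutylamino in place of dimethylamino on the carbonyl carbon gives a 9.3-fold higher number from compound 1 to compound 3 (0.97 log units; beyond the scatter) in this assay while the 4-chlorophenyl group stays fixed. The dose needed in this assay therefore responds to the substituents on the amide nitrogen as well as to the aromatic group changed in compound 2, and here the butyl chains go with the higher number. No measurement at hand accounts for this rise.

As far as these compounds go, with only two amides compared on this core, it remains open whether a diethylamino amide, a ring amine such as piperidine or a primary amide would stay nearer to compound 1 or move further from it. From the compounds shown here alone, it also remains open whether dibutylamino would change the number similarly alongside the 5-bromothiophen-2-yl group.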